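The compounds below may be only part of what the source reports. "The series", "measured", "known", "first", "only" and "open" are said of these compounds alone.

Measured so far in an ADME assay on L6 cells (Rattus norvegicus) for cytotoxicity, read by resazurin assay, with a stated time of 70 h; on this read-out higher numbers stand for weaker inhibition and lower numbers for stronger inhibition:
- compound 1 `CC(=O)Oc1ccc2c(c1)C(C)=CC(C)(C)N2Cc1ccccc1`: 24000 nM
- compound 2 `CC(=O)Oc1ccc2c(c1)C(C)=CC(C)(C)N2Cc1ccc(Cl)cc1`: 22000 nM
- compound 3 `COc1cc(OC)cc(C(=O)Oc2ccc3c(c2)C(C)=CC(C)(C)N3Cc2ccccc2)c1`: 24000 nM

Level with compound 1, compound 3 stands at 24000 nM, and all three values lie within the scatter of one another. Compound 4 `COc1cc(OC)cc(C(=O)Oc2ccc3c(c2)C(C)=CC(C)(C)N3Cc2ccc(Cl)cc2)c1`, still unmeasured, differs from compound 3 by chloro in place of hydrogen on an aromatic carbon, turning benzyl into 4-chlorobenzyl: chloro in place of hydrogen on an aromatic carbon.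

The same exchange has been measured once, with methyl on the carbonyl carbon, and it gave a 1.1-fold lower number from compound 1 to compound 2 (0.04 log units; within the scatter). The other measured step, no change at the digits printed from compound 1 to compound 3 (within the scatter), shows that 3,5-dimethoxyphenyl in place of that methyl also left the number within the scatter. Within the data shown here, with only this one matched pair to go on, no step beyond the scatter is expected in this assay. The expected step is a 1.1-fold lower number from compound 3 to compound 4 (0.04 log units; within the scatter), which would stay within the scatter. For compound 4 the estimated value is 22000 nM, with an expected range from 12000 nM to 40000 nM.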

Compound 4, half-maximal inhibitory concentration: > 190000 nM
Compound 4 was reported as a limit; the forecaster's own chance of this, stated with the estimate: 5%; at least 8.6-fold (0.93 log units) between middle value and limit.
By their numbers in this assay, from the lowest: compounds 2, 1 and 3 (each within the scatter of the next). At a limit, above all of these: compound 4.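

In this assay, compound 4 is reported only as a limit, > 190000 nM, not as a number. Chloro in place of hydrogen on this aromatic carbon, which stayed within the scatter with methyl on the carbonyl carbon, gives an at least 7.9-fold higher number from compound 3 to compound 4 (0.89 log units; beyond the scatter), so the outcome of this change depends on the group at the other end of the molecule: the same change on two cores in this assay, a 1.1-fold lower number (0.04 log units; within the scatter) from compound 1 to compound 2 and an at least 7.9-fold higher number (0.89 log units; beyond the scatter) from compound 3 to compound 4, at least 8.6-fold (0.93 log units) apart, beyond the scatter of two such steps. Read the other way, 3,5-dimethoxyphenyl in place of methyl on a carbonyl carbon gives an at least 8.6-fold higher number from compound 2 to compound 4 (0.93 log units; beyond the scatter) once the 4-chlorobenzyl is present, so neither change can be read alone: the same change on two cores in this assay, no change at the digits printed (within the scatter) from compound 1 to compound 3 and an at least 8.6-fold higher number (0.93 log units; beyond the scatter) from compound 2 to compound 4, at least 8.6-fold (0.93 log units) apart, beyond the scatter of two such steps.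

From the compounds shown here alone, the true size of both steps stays open, since one end of each is a limit. Also open, going by these compounds, is whether bromo or methoxy in place of the chloro, or a 4-chlorobenzyl with an ethyl or a plain phenyl on the carbonyl carbon, would behave as compound 4 does.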